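Methyl in place of methoxy on the anilino ring

A few compounds are considered here, and "the series" means these few. Any claim that something is new, unique, unknown or untested is made for them only; others in the source may bear on it.

Compound 2 `COc1ccccc1Nc1nc(SCc2cn(Cc3ccccc3Cl)nn2)nc(-c2ccccc2)c1C#N` was measured in an ADME assay on HET-1A cells (Homo sapiens) for inhibition, read by MTT assay, with a stated time of 72 h; a lower number here means a stronger inhibitor, a higher number a weaker inhibitor; compound 2 gives 16200 nM. Compound 1 `COc1ccc(Nc2nc(SCc3cn(Cc4ccccc4Cl)nn3)nc(-c3ccccc3)c2C#N)cc1` gives 18100 nM, so the two stand within the scatter of each other. Among the compounds with values here, the only measured step, a 1.1-fold lower number from compound 1 to compound 2 (0.05 log units; within the scatter), changes where the methoxy sits and is itself within the scatter. Compound 3 `Cc1ccccc1Nc1nc(SCc2cn(Cc3ccccc3Cl)nn2)nc(-c2ccccc2)c1C#N` differs from compound 2 by methyl in place of methoxy on an aromatic carbon. Within the data shown here, no measured step swaps methoxy for methyl, so that single step offers only weak guidance. The account therefore expects no change beyond the scatter, a 1.0-fold lower number from compound 2 to compound 3 (0.01 log units; within the scatter). Compound 3 is estimated at 16000 nM, between 6000 nM and 45000 nM.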

Compound 3, half-maximal inhibitory concentration: 23000 nM
Compound 3: middle estimate off by 1.4-fold (0.16 log units), on the low side, and the stated range covers the measured number.
By their numbers in this assay, from the lowest: compounds 2, 1 and 3 (each within the scatter of the next).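

In this assay, methyl in place of methoxy gives a 1.4-fold higher number from compound 2 to compound 3 (0.15 log units; within the scatter) and so does not move the number beyond the scatter at this aromatic carbon. Changing both the group and its place on the ring, 2-methylphenyl in place of 4-methoxyphenyl, gives a 1.3-fold higher number from compound 1 to compound 3 (0.10 log units; within the scatter) and also stays within the scatter. No measurement at hand offers an explanation for these steps.
Methoxy and methyl alone leave open whether any group on this aromatic carbon can shift the number beyond the scatter. An amine or a carboxylic acid there remains an open case.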